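Bromo for chloro on the core of compound 1

This account rests on a few compounds, and the source may have more. Where it says the series, first, only, none or still open, it means among the compounds named here.

Measured compounds:
compound 1 `Cc1ccc(S(=O)(=O)N2CCC(Cl)CC2)cc1` in a functional assay on WiDr cells (Homo sapiens) for antiproliferative activity, read by sulforhodamine B assay, with a stated time of 48 h; a lower number here means a stronger inhibitor of growth, a higher number a weaker inhibitor of growth: > 100000 nM
compound 2 `Cc1ccc(S(=O)(=O)N2CC[C@@H](Cl)C[C@@H]2CC(C)C)cc1` in this assay: 22000 nM
compound 3 `Cc1ccc(S(=O)(=O)N2CC[C@@H](Cl)C[C@@H]2c2ccccc2)cc1` in this assay: 37000 nM

Compound 1 stands at the weak end of the series; its value > 100000 nM is a limit of the assay and not a number (the limit of > 100000 nM in this assay, at which 1 of the 3 values shown sits). Compound 2 gives 22000 nM in this assay. Compound 3 gives 37000 nM in this assay. Both measured steps away from compound 1 place a group on the ring carbon that bears a large group: an at least 4.5-fold lower number from compound 1 to compound 2 (0.65 log units; beyond the scatter) and an at least 2.7-fold lower number from compound 1 to compound 3 (0.43 log units; beyond the scatter). Between the two substituted compounds, a 1.7-fold higher number from compound 2 to compound 3 (0.23 log units; within the scatter).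

Compound 4 `Cc1ccc(S(=O)(=O)N2CCC(Br)CC2)cc1` differs from compound 1 by bromo in place of chloro on a saturated ring carbon. Going by the values given here, no measured step changes the halogen on this ring carbon; the measured steps all concern another ring carbon and leave the chloro untouched. The swap of one halogen atom for another is far smaller than the additions that produced the measured steps. The expectation for compound 4 in this assay is a step of a number no higher from compound 1 to compound 4 (the limit leaves the size open), within the scatter, with the value likely again reported as a limit. The estimate for compound 4 is 100000 nM, with a range from 30000 nM to 300000 nM.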

Compound 4, concentration for 50% growth inhibition: > 100000 nM
Compound 4 was reported as a limit; the forecaster's own chance of this, stated with the estimate: 70%; the middle value lies on the limit itself.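

Going by these compounds alone, compound 1 and compound 4 are each reported only as a limit and not as a number, so no step between them can be read: the limit of > 100000 nM in this assay, at which 2 of the 4 values shown sit.

The compounds shown leave open whether bromo in place of chloro on a saturated ring carbon changes growth inhibition on the cores of compound 2 and compound 3, where the values are measurable numbers.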